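A few compounds are considered here, and "the series" means these few. Any claim that something is new, unique, unknown or untested is made for them only; others in the source may bear on it.

Measured so far:
compound 1 `COc1ccc2c(=O)cc(/C=C/c3ccc(OC(F)(F)F)cc3)oc2c1` — > 40000 nM
compound 2 `COc1cccc2oc(/C=C/c3ccc(OC(F)(F)F)cc3)cc(=O)c12` — > 40000 nM

In a functional assay on A549 cells (Homo sapiens) for antiproliferative activity, read by MTT assay, with a stated time of 12 h (a higher number here means a weaker inhibitor, a lower number a stronger inhibitor), compound 1 gives only a limit, > 40000 nM. Compound 2 likewise gives only a limit, > 40000 nM. Compound 2 therefore stands at the limit of > 40000 nM in this assay, at which 2 of the 2 values shown sit, and no actual number is known for it. Compound 3 `O=c1cc(/C=C/c2ccc(OC(F)(F)F)cc2)oc2ccccc12` differs from compound 2 by hydrogen in place of methoxy on an aromatic carbon. Within the data shown here, both measured values are limits, so no step between measured compounds exists, and there is no basis for expecting compound 3 to move beyond the usual scatter in either direction. Compound 3 is thus estimated at 40000 nM, within 20000 nM to 100000 nM, an expected step of a number no higher from compound 2 to compound 3 (the limit leaves the size open).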

Compound 3, half-maximal inhibitory concentration: 15600 nM
The estimate for compound 3 lay 2.6-fold (0.41 log units) above the measured number; the measured number lies below the stated range.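

In this assay, among these compounds, compound 3 is the first compound here to give an actual number rather than a limit. Hydrogen in place of methoxy gives an at least 2.5-fold lower number from compound 2 to compound 3 (0.40 log units; beyond the scatter), and the same exchange likewise gives an at least 2.5-fold lower number from compound 1 to compound 3 (0.40 log units; beyond the scatter). Each step is a minimum and its full size cannot be read, because the starting values are limits: the limit of > 40000 nM in this assay, at which 2 of the 3 values shown sit.

As far as these compounds go, whether an amine, a fluorine or a longer ether chain on this aromatic carbon would give a lower or higher number stays open. So does whether any such group would do better than hydrogen.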